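Thioester analogue of a dihydropyrimidinone adenosine ligand

The source may report more compounds than this note shows. Statements on the series, on what has been measured and on what is new or still open speak of the compounds shown alone.

Measured compounds:
compound 1, `CCCC(=O)C1=C(C)NC(=O)NC1c1ccco1`: 1%
compound 2, `CCCC(=O)C1=C(C)NC(=O)NC1c1ccoc1`: 1%
compound 3, `CCCC(=O)C1=C(C)NC(=O)NC1c1ccsc1`: 6%

In an assay on membranes from CHO cells for displacement of a labelled ligand from adenosine receptor A1 (Homo sapiens), read by scintillation counting, with a stated time of 60 min, tested at 1 uM (a higher number here means more inhibition at the concentration tested (going by the name of the read-out), a lower number less inhibition), compound 2 gives 1%. It stands level with compound 1 at the digits printed, and the two together hold the lowest numbers of the three; its nearest neighbour is compound 1, no change at the digits printed from compound 1 to compound 2 (within the scatter), and its furthest is compound 3, a number 5 percentage points higher from compound 2 to compound 3 (within the scatter). The step to compound 4, `CCSC(=O)C1=C(C)NC(=O)NC1c1ccoc1`, is ethylsulfanyl in place of propyl on a carbonyl carbon.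

Among the compounds with values here, none of the measured steps touches the carbonyl carbon. The three measured steps all exchange the aromatic group on the saturated ring carbon: no change at the digits printed from compound 1 to compound 2 (within the scatter), a number 5 percentage points higher from compound 1 to compound 3 (within the scatter) and a number 5 percentage points higher from compound 2 to compound 3 (within the scatter), each within the scatter. The data therefore give no direct guide to the new exchange, only a picture of a series that sits at the bottom of the scale in this assay whatever is varied so far. On that basis compound 4 is expected to show a number 1 percentage points higher from compound 2 to compound 4 (within the scatter). Compound 4 is estimated at 2%, in a range from -8% to 12%.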

Compound 4, a percentage reported as inhibition, at one concentration (the size of the read-out at that concentration, not a potency): 3%
Compound 4: middle estimate off by 1 percentage points, on the low side; the measured number falls inside the stated range.
By their numbers in this assay, from the lowest: compounds 1, 2, 4 and 3 (each within the scatter of the next).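

On the carbonyl carbon, the exchange of propyl for ethylsulfanyl gives, in this assay, a number 2 percentage points higher from compound 2 to compound 4 (within the scatter). Within the data shown here, this is the first view of that position, and it shows that putting sulfur into the chain there, with the heavy-atom count unchanged, moves the number no further than the scatter, just as the exchanges of the aromatic group did. Nothing available bears on why the number stays where it does.

Going by these compounds, whether another group on the carbonyl carbon, such as an amine, a methoxy group or a longer alkyl chain, would lift the number clear of the scatter remains open. So does whether ethylsulfanyl gives the same picture with furan-2-yl or thiophen-3-yl on the saturated ring carbon.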